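A few compounds are considered here, and "the series" means these few. Any claim that something is new, unique, unknown or untested is made for them only; others in the source may bear on it.

Compound 3 `COc1cc(N)c(Cl)cc1C(=O)CCC1CCN(CCNS(=O)(=O)c2ccc(C)cc2)CC1` gives 15% in an assay on HEK293 cells for displacement of a labelled ligand from 5-hydroxytryptamine receptor 6 (Homo sapiens), with a stated time of 60 min, tested at 1 uM, in the presence of a further agent that is not named here (a lower number here means a weaker effect, a higher number a stronger effect of the compound at the concentration tested), the lowest of the three numbers: compound 1 `COc1cc(N)c(Cl)cc1C(=O)CCC1CCN(CCNS(=O)(=O)c2ccc3c(c2)NC(=O)CO3)CC1` gives 40% and compound 2 `COc1ccc(S(=O)(=O)NCCN2CCC(CCC(=O)c3cc(Cl)c(N)cc3OC)CC2)cc1Br` gives 72%. Compound 4 `COc1ccc(S(=O)(=O)NCCN2CCC(CCC(=O)c3cc(Cl)c(N)cc3OC)CC2)cc1OC` differs from compound 3 in one place, (3,4-dimethoxyphenyl in place of 4-methylphenyl on a sulfonyl sulfur). For the measured compounds named here, the step that bears most on this change is the one between compound 2 and compound 3, where a number 57 percentage points lower from compound 2 to compound 3 (beyond the scatter); the step from compound 1 to compound 2, a number 32 percentage points higher from compound 1 to compound 2 (beyond the scatter), also shows a substituted aryl ring on the sulfonyl sulfur raising the number. Compound 4 shares the 4-methoxy with compound 2, so a gain beyond the scatter is expected, a number 35 percentage points higher from compound 3 to compound 4 (beyond the scatter), though not necessarily the full size seen for compound 2. Compound 4 is therefore estimated at 50%, between 25% and 75%.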

Compound 4, a percentage reported as inhibition, at one concentration (the size of the read-out at that concentration, not a potency): 58%
Estimate against measurement, compound 4: 8 percentage points below, within the range that was stated.
By their numbers in this assay, from the lowest: compound 3; then compound 1; then compound 4; then compound 2.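

With 3,4-dimethoxyphenyl on a sulfonyl sulfur, this assay shows a number 43 percentage points higher from compound 3 to compound 4 (beyond the scatter) and so a gain over 4-methylphenyl does not require bromo. The bromo still counts: methoxy in place of bromo on an aromatic carbon brings a number 14 percentage points lower from compound 2 to compound 4 (beyond the scatter) and the 3,4-dimethoxyphenyl group also gives a number 18 percentage points higher from compound 1 to compound 4 (beyond the scatter) in place of the larger fused group. Nothing available explains these differences. Open, as far as these compounds go, is how an unsubstituted phenyl, or a phenyl bearing chloro or an amine, would stand on the sulfonyl sulfur. From the compounds shown here alone, each number also gives the size of the effect at one concentration only, so whether the stronger and weaker effects seen here hold at other concentrations remains open.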